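Swapping the group on the carbonyl carbon of compound 3

The source may hold more compounds than are shown below. What is called first, only, known or untested is meant among the compounds shown, and "the series" means these compounds.

- compound 1 `CCCCc1nc(C)c(CCC(=O)OCC)c(=O)n1Cc1ccc(-c2ccccc2-c2nnn[nH]2)cc1` gives 0.066 mg/kg
- compound 2 `CCCCc1nc(C)c(CC(=O)O)c(=O)n1Cc1ccc(-c2ccccc2-c2nnn[nH]2)cc1` gives 0.13 mg/kg
- compound 3 `CCCCc1nc(C)c(CC(=O)N2CCC[C@H]2C(N)=O)c(=O)n1Cc1ccc(-c2ccccc2-c2nnn[nH]2)cc1` gives 0.023 mg/kg

In an in vivo functional assay on the whole organism for inhibition, with Rattus norvegicus as the target (on this read-out higher numbers stand for an effect only at larger amounts of compound and lower numbers for an effect already at smaller amounts), compound 3 has the lowest of the three numbers, and its gaps to both others lie beyond the scatter. Compound 4 `CCCCc1nc(C)c(CC(=O)N2CCOCC2)c(=O)n1Cc1ccc(-c2ccccc2-c2nnn[nH]2)cc1` puts morpholin-4-yl in place of 2-carbamoylpyrrolidin-1-yl on a carbonyl carbon. For the measured compounds named here, no measured step tests morpholin-4-yl directly. The nearest evidence is the change on that same carbonyl carbon, a 5.7-fold lower number from compound 2 to compound 3 (0.75 log units; beyond the scatter), and the related 2.9-fold lower number from compound 1 to compound 3 (0.46 log units; beyond the scatter). Since 2-carbamoylpyrrolidin-1-yl leaves, part of that drop may be lost. A modest rise in this assay is therefore expected, a 2.2-fold higher number from compound 3 to compound 4 (0.34 log units; beyond the scatter). For compound 4 the estimated value is 0.05 mg/kg, within an expected range of 0.02 mg/kg to 0.13 mg/kg.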

Compound 4, dose for half-maximal effect: 0.018 mg/kg
For compound 4 the middle estimate is 2.8-fold (0.44 log units) above the measured one; measured number outside the range, below it.
By their numbers in this assay, from the lowest: compounds 4 and 3 (each within the scatter of the next); then compounds 1 and 2 (each within the scatter of the next).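

In this assay, morpholin-4-yl serves on this carbonyl carbon as well as 2-carbamoylpyrrolidin-1-yl (a 1.3-fold lower number from compound 3 to compound 4 (0.11 log units; within the scatter)), so the low number does not depend on the hydrogen-bond donor or the defined stereocentre that leave. A second ring amide also stands clear of the acid (a 7.2-fold lower number from compound 2 to compound 4 (0.86 log units; beyond the scatter)) and the ester (a 3.7-fold lower number from compound 1 to compound 4 (0.56 log units; beyond the scatter)), so the earlier drop is not unique to compound 3. No available measurement explains these steps. Still open, going by these compounds, is whether piperidin-1-yl or dimethylamino on this carbonyl carbon would give a similar number.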